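The source may hold more compounds than are shown below. What is called first, only, known or untested is meant among the compounds shown, and "the series" means these compounds.

Three measured compounds share a core that carries an ethyl group, a carbonyl and a fluorine, together with an amine-containing ring and a second aromatic group. Compound 1 `CCn1cc(-c2nc3ccccc3o2)c(=O)c2cc(F)c(N3CCNC(C)C3)c(F)c21` carries a 1,3-benzoxazol-2-yl group, as does compound 2 `CCn1cc(-c2nc3ccccc3o2)c(=O)c2cc(F)c(N3CCN(C)CC3)cc21`; the difference between the two cores is not broken down here. Compound 3 `CCn1cc(-c2nc3ccccc3s2)c(=O)c2cc(F)c(N3CCN(C)CC3)cc21` differs from compound 2 in one place: 1,3-benzothiazol-2-yl in place of 1,3-benzoxazol-2-yl on an aromatic carbon. In a functional assay on KB cells (Homo sapiens) for cytotoxicity, read by MTT assay, with a stated time of 48 h (on this read-out lower numbers stand for stronger inhibition and higher numbers for weaker inhibition), compound 2 gives 87400 nM, while compound 3 gives 19000 nM, so that a 4.6-fold lower number from compound 2 to compound 3 (0.66 log units; beyond the scatter). In this assay compound 1 gives 18900 nM; its value and that of compound 3 lie within the scatter of each other, so no order between them is claimed, whereas compound 1 sits clearly apart from compound 2.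

Compound 4 `CCn1cc(-c2nc3ccccc3s2)c(=O)c2cc(F)c(N3CCNC(C)C3)c(F)c21` is not yet measured. It arises from compound 1 by the same change: 1,3-benzothiazol-2-yl in place of 1,3-benzoxazol-2-yl on an aromatic carbon. The surroundings of the place match word for word those of the change from compound 2 to compound 3, so a step of similar size seems reasonable. Among the measured compounds shown here, only one example of the change is available, and it sits on a core whose relation to compound 1 is not broken down here, so the expectation carries real uncertainty. In this assay compound 4 is expected to show a 3.8-fold lower number from compound 1 to compound 4 (0.58 log units; beyond the scatter). That expectation rests on the earlier step, which gave a 4.6-fold lower number from compound 2 to compound 3 (0.66 log units; beyond the scatter). The estimate for compound 4 is 5000 nM, with a likely range from 1500 nM to 15000 nM.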

Compound 4, half-maximal inhibitory concentration: 24300 nM
Compound 4: the middle estimate sits 4.9-fold (0.69 log units) below what was measured, and the stated range ends below it.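

In this assay, placing 1,3-benzothiazol-2-yl where 1,3-benzoxazol-2-yl stood gives a 1.3-fold higher number from compound 1 to compound 4 (0.11 log units; within the scatter), so on this core the two groups cannot be told apart. The change therefore does not carry over in size from one core to the other, even though the surroundings of the place match: the same change on two cores in this assay, a 4.6-fold lower number (0.66 log units; beyond the scatter) from compound 2 to compound 3 and a 1.3-fold higher number (0.11 log units; within the scatter) from compound 1 to compound 4, 5.9-fold (0.77 log units) apart, beyond the scatter of two such steps. Among the compounds shown here, this shows that a step measured on one core is not a safe guide to the same step on another core, but with only two pairs it does not show which difference between the cores goes with the different outcomes, and it gives no general rule for either group.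

As far as these compounds go, the two cores differ in more than one place, so it remains open whether the amine-containing ring, the extra fluorine of compound 1 or both together go with the difference between the two steps, and pairs differing in only one of these places would be needed to separate them. From the compounds shown here alone, it also remains open how a different group in the same place, such as a plain phenyl ring or an amide, would behave on either core.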